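A few compounds are considered here, and "the series" means these few. Any claim that something is new, unique, unknown or untested is made for them only; others in the source may bear on it.

Two measured compounds share one core and differ at both ends of it. In a functional assay on A549 cells (Homo sapiens) for antiproliferative activity, read by sulforhodamine B assay, with a stated time of 72 h (a lower number here means a stronger inhibitor, a higher number a weaker inhibitor), compound 1 `COc1ncc(-c2ccc3ncnc(Nc4cnn(CCCO)c4)c3c2)cc1NS(C)(=O)=O` gives 3600 nM. In this assay compound 2 `COc1ncc(-c2ccc3ncnc(Nc4ccc(OCCO)cc4)c3c2)cc1NS(=O)(=O)c1ccc(F)cc1F` gives 2690 nM. Compound 2 holds the lower of the two numbers, yet its gap to compound 1 lies within the scatter of repeated measurements, so the two cannot be told apart on these data. Compound 3 `COc1ncc(-c2ccc3ncnc(Nc4ccc(OCCO)nc4)c3c2)cc1NS(=O)(=O)c1ccc(F)cc1F` has not yet been measured. It differs from compound 2 in one place: 6-(2-hydroxyethoxy)pyridin-3-yl in place of 4-(2-hydroxyethoxy)phenyl on a nitrogen on an aromatic ring. Going by the values given here, no pair of measured compounds isolates this change, so nothing measured here speaks to its size. The step from compound 2 is expected to be a 1.1-fold lower number from compound 2 to compound 3 (0.03 log units; within the scatter), which is none beyond the scatter. Compound 3 is therefore expected to give about 2500 nM in this assay, within a range of 1000 nM to 6500 nM.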

Compound 3, half-maximal inhibitory concentration: 4120 nM
The estimate for compound 3 lay 1.6-fold (0.22 log units) below the measured number, within the range that was stated.
By their numbers in this assay, from the lowest: compounds 2, 1 and 3 (each within the scatter of the next).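

In this assay, going by these compounds alone, the exchange of 4-(2-hydroxyethoxy)phenyl for 6-(2-hydroxyethoxy)pyridin-3-yl on a nitrogen on an aromatic ring now has a measured size, a 1.5-fold higher number from compound 2 to compound 3 (0.19 log units; within the scatter), where the earlier compounds offered no pair that isolated it. This step lies within the scatter, so the two compounds cannot be told apart on these data, and this position tolerates the change without a measurable loss or gain in this read-out. Nothing available here offers an explanation for this result.

The compounds shown leave open whether replacing the hydroxyl of the 2-hydroxyethoxy chain with an amine or a carboxylic acid, or using a longer chain, would produce a step beyond the scatter. Compound 1 also differs from compound 2 at both ends, so neither end's contribution can be read separately.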